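The source may report more compounds than this note shows. Statements on the series, on what has been measured and on what is new or still open speak of the compounds shown alone.

Measured so far:
- compound 1, `O=C1NC(=O)/C(=C/c2ccc(OCCSc3nnc(-c4ccc(Cl)cc4)[nH]3)cc2)S1`, in a functional assay on the whole organism (strain Wistar) with Rattus norvegicus as the target, with a stated time of 15 days, at a dose of 3 mg/kg by the oral route (a higher number here means a stronger effect of the compound at the dose given, a lower number a weaker effect), compound 1 gives 23.9%
- compound 2, `O=C1NC(=O)/C(=C/c2ccc(OCCSc3nnc(-c4ccccc4)o3)cc2)S1`, in this assay compound 2 gives 21.6%

Compound 1 and compound 2 share the same core and differ only in the five-membered aromatic ring and in what sits on it. Among the compounds with values here, their two values in this assay lie within the usual scatter of each other, so compound 2 stands alongside compound 1 rather than apart from it; no step between them can be read as real.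

Compound 3, `O=C1NC(=O)/C(=C/c2ccc(OCCSc3nnc(Cc4ccccc4)o3)cc2)S1`, has not yet been tested. It differs from compound 2 as follows: benzyl in place of phenyl on an aromatic carbon. Within the data shown here, no measured pair shows what this kind of change does here, so there is no basis for expecting a step beyond the scatter in either direction. Compound 3 is therefore estimated at 20%, in the range 8% to 32%, which amounts to an expected step of a number 1.6 percentage points lower from compound 2 to compound 3 (within the scatter).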

Compound 3, a percentage reported as activity, at one dose (the size of the read-out at that dose, not a potency): 18.5%
The estimate for compound 3 lay 1.5 percentage points above the measured number; the range from low to high includes it.
By their numbers in this assay, from the lowest: compounds 3, 2 and 1 (each within the scatter of the next).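

In this assay, benzyl in place of phenyl on this aromatic carbon gives a number 3.1 percentage points lower from compound 2 to compound 3 (within the scatter). Within the data shown here, this is the first comparison that changes a single group, and it shows no step that can be read as real. At this one dose, then, the read-out tolerates the swap from phenyl to benzyl at this position, although a single pair says nothing about other groups there. Nothing measured here speaks to the reason for this result.

The compounds shown leave open whether a group of another kind on this carbon, such as an amine or a carboxylic acid, or a longer chain ending in phenyl, would move the read-out beyond the scatter. They also leave open how these compounds would compare at other doses.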